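Adding a second chloro to a benzylpurine: compound 4 expected

This account rests on a few compounds, and the source may have more. Where it says the series, first, only, none or still open, it means among the compounds named here.

Measured so far:
compound 1 `ClCc1ccc(Cn2cnc3c(Cl)ncnc32)cc1` 77600 nM
compound 2 `ClCc1cccc(Cn2cnc3ncnc(Cl)c32)c1` 3980 nM
compound 3 `ClCc1ccc(Cn2cnc3nc(Cl)nc(Cl)c32)cc1` 17000 nM

In a functional assay on MCF7 cells (Homo sapiens) for cytotoxicity, read by sulforhodamine B assay, with a stated time of 48 h (on this read-out lower numbers stand for stronger inhibition of growth and higher numbers for weaker inhibition of growth), compound 1 gives the highest number of the three, with compound 3 nearest and compound 2 furthest, both gaps beyond the scatter. Compound 4 `ClCc1ccc(Cn2cnc3c(Cl)nc(Cl)nc32)cc1` differs from compound 1 by chloro in place of hydrogen on an aromatic carbon between two ring nitrogen atoms. Among the compounds with values here, no directly comparable pair has been measured, so the size of this step is open. Compound 4 is expected to give a somewhat lower number than compound 1, a step of a 5.2-fold lower number from compound 1 to compound 4 (0.71 log units; beyond the scatter), of moderate size. For compound 4 the estimate is 15000 nM, within a range of 4000 nM to 60000 nM.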

Compound 4, concentration for total growth inhibition: 3980 nM
Estimate against measurement, compound 4: 3.8-fold (0.58 log units) above; measured number outside the range, below it.
By their numbers in this assay, from the lowest: compounds 2 and 4 (each within the scatter of the next); then compound 3; then compound 1.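

In this assay the change of hydrogen to chloro on an aromatic carbon between two ring nitrogen atoms gives a 19-fold lower number from compound 1 to compound 4 (1.29 log units; beyond the scatter). Within the data shown here, this is the first single change that can be read, and it shows that this position responds strongly: one added chlorine atom, with no ring and no net charge, produces a large step. Nothing available bears on why the step is this large. The compounds shown leave open whether chloro is needed here or whether an amine, a methoxy group or a methyl group on the same carbon would give a similar step.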